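This account rests on a few compounds, and the source may have more. Where it says the series, first, only, none or still open, it means among the compounds named here.

Compound 1, `N#Cc1c(-c2ccccc2O)c(C#N)c(=O)n(/N=C/c2cn(-c3ccccc3)nc2-c2ccccc2)c1N`, gives 162 ug/mL in an ADME assay on NIH3T3 cells (Mus musculus) for cytotoxicity, read by MTT assay; a lower number here means a stronger inhibitor, a higher number a weaker inhibitor.
Compound 2, `N#Cc1c(-c2ccccc2Cl)c(C#N)c(=O)n(/N=C/c2cn(-c3ccccc3)nc2-c2ccccc2)c1N`, gives 84 ug/mL in this assay.
Compound 3, `N#Cc1c(-c2cccc(Cl)c2)c(C#N)c(=O)n(/N=C/c2cn(-c3ccccc3)nc2-c2ccccc2)c1N`, gives 52 ug/mL in this assay.

Among these three numbers, compound 3 separates clearly only from compound 1: the step of a 3.1-fold lower number from compound 1 to compound 3 (0.49 log units; beyond the scatter) lies beyond the scatter. Against compound 2 the step of a 1.6-fold lower number from compound 2 to compound 3 (0.21 log units; within the scatter) stays within the scatter, so the two cannot be told apart on these data. The step of a 1.9-fold lower number from compound 1 to compound 2 (0.29 log units; within the scatter) is likewise within the scatter.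

Compound 4, `N#Cc1c(-c2ccc(Cl)cc2)c(C#N)c(=O)n(/N=C/c2cn(-c3ccccc3)nc2-c2ccccc2)c1N`, has not yet been measured. It differs from compound 3 in one place: 4-chlorophenyl in place of 3-chlorophenyl on an aromatic carbon. For the measured compounds named here, the one measured step that bears on moving a chlorine around the same phenyl ring is a 1.6-fold lower number from compound 2 to compound 3 (0.21 log units; within the scatter), and it stayed within the scatter. Nothing measured here points to a larger effect when the chlorine moves again.

The number for compound 4 in this assay is therefore expected to stay close to that of compound 3, an expected step of a 1.0-fold lower number from compound 3 to compound 4 (0.02 log units; within the scatter). The estimate for compound 4 is 50 ug/mL, in a range from 25 ug/mL to 100 ug/mL.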

Compound 4, half-maximal inhibitory concentration: 64 ug/mL
The estimate for compound 4 lay 1.3-fold (0.11 log units) below the measured number; the measured number falls inside the stated range.
By their numbers in this assay, from the lowest: compounds 3, 4, 2 and 1 (each within the scatter of the next, the first and the last beyond it).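

In this assay the place of the chlorine on this phenyl ring makes no readable difference: the step of a 1.2-fold higher number from compound 3 to compound 4 (0.09 log units; within the scatter) and the step of a 1.3-fold lower number from compound 2 to compound 4 (0.12 log units; within the scatter) both stay within the scatter, so the 2-chlorophenyl, 3-chlorophenyl and 4-chlorophenyl compounds cannot be told apart. The step of a 2.5-fold lower number from compound 1 to compound 4 (0.40 log units; beyond the scatter) lies beyond the scatter, so compound 4 joins compound 3 in separating from the 2-hydroxyphenyl compound, although compound 2, the exception among the chlorophenyl compounds, does not separate from it. No measurement is available here to explain these numbers.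

On these data alone, the phenyl ring carries only chloro or hydroxy in these compounds, so the effect of an amine, a methoxy group or a carboxylic acid on it remains open. As far as these compounds go, whether 3-hydroxyphenyl or 4-hydroxyphenyl would give numbers like those of the chlorophenyl compounds also remains open.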